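A few compounds are considered here, and "the series" means these few. Any claim that something is new, unique, unknown or untested is made for them only; others in the source may bear on it.

Compound 1 `O=C(Nc1ccccc1O)C1CCc2ccccc2N1C(=O)c1ccc(Cl)cc1` gives 20200 nM in a functional assay on HCT-15 cells (Homo sapiens) for cytotoxicity, read by sulforhodamine B assay, with a stated time of 72 h; a lower number here means a stronger inhibitor of growth, a higher number a weaker inhibitor of growth.
Compound 2 `O=C(Nc1ccccc1O)C1CCc2ccccc2N1C(=O)c1ccccc1` gives 3830 nM in this assay.

Going by the values given here, of the two measured compounds, compound 2 has the lowest number in this assay; the only other compound is compound 1, and the step of a 5.3-fold lower number from compound 1 to compound 2 (0.72 log units; beyond the scatter) is beyond the scatter. Compound 3 `O=C(Nc1ccccc1O)C1CCc2ccccc2N1` has not yet been measured. It differs from compound 2 in one place: hydrogen in place of benzoyl on a nitrogen on an aromatic ring in a ring. Among the compounds with values here, no measured step removes this group; the one step that exists, a 5.3-fold lower number from compound 1 to compound 2 (0.72 log units; beyond the scatter), alters only a substituent on the benzoyl and shows that changes there shift the number by a modest amount. Removing the whole benzoyl is a larger change than any that has been measured, so the direction is uncertain. Given that compound 2 stands at 3830 nM, compound 3 is expected to give a higher number, estimated at 12000 nM in this assay, within a range of 2500 nM to 60000 nM, a step of a 3.1-fold higher number from compound 2 to compound 3 (0.50 log units; beyond the scatter).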

Compound 3, concentration for 50% growth inhibition: 5610 nM
Beside the measured number, compound 3's estimate is 2.1-fold (0.33 log units) above it; the measured number falls inside the stated range.
By their numbers in this assay, from the lowest: compounds 2 and 3 (each within the scatter of the next); then compound 1.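

With hydrogen in place of benzoyl on the nitrogen, this assay gives a 1.5-fold higher number from compound 2 to compound 3 (0.17 log units; within the scatter) and so the whole benzoyl can leave that nitrogen without a shift beyond the scatter. The earlier compounds showed only what a chloro on the benzoyl does, whereas a 3.6-fold lower number from compound 1 to compound 3 (0.56 log units; beyond the scatter) is a step beyond the scatter, which sets compound 1 apart from both compound 2 and compound 3 among these three. No measurement shown here accounts for this result. The compounds shown leave open what an acetyl group, a simple methyl or a longer alkyl chain on that nitrogen would give. They also leave open what a different substituent on the benzoyl, such as a methoxy group or a fluoro, would give in place of the chloro of compound 1.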